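A few compounds are considered here, and "the series" means these few. Any claim that something is new, unique, unknown or untested is made for them only; others in the source may bear on it.

Measured in an assay on isolated protein for binding affinity to Adrenergic receptor alpha-1 (Homo sapiens), read by radioligand binding; on this read-out higher numbers stand for weaker inhibition and lower numbers for stronger inhibition:
compound 1, `Oc1ccc(CC(O)CN2CCC(Cc3ccccc3)CC2)cc1`: 305 nM
compound 2, `Oc1ccc(CC(O)CN2CCC(O)(Cc3ccc(Br)cc3)CC2)cc1`: 2440 nM
compound 3, `Oc1ccc(CC(O)CN2CCC(O)(Cc3ccccc3)CC2)cc1`: 4510 nM

Compound 3 gives the highest of these three numbers. Its nearest neighbour is compound 2, and that gap, a 1.8-fold higher number from compound 2 to compound 3 (0.27 log units; within the scatter), comes from hydrogen in place of bromo on an aromatic carbon. The furthest is compound 1, with a 15-fold higher number from compound 1 to compound 3 (1.17 log units; beyond the scatter), where compound 3 carries a hydroxy in place of hydrogen on a saturated ring carbon.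

Compound 4, `Oc1ccc(CC(O)CN2CCC(O)(Cc3ccc(Cl)cc3)CC2)cc1`, has not yet been measured. It differs from compound 3 by chloro in place of hydrogen on an aromatic carbon, sitting para to a large group, so that phenyl becomes 4-chlorophenyl and benzyl becomes 4-chlorobenzyl. Among the measured compounds shown here, the only step that bears on this is the bromo one: going from compound 2 to compound 3 stayed within the scatter, and chloro on the same aromatic carbon is the closest comparison available. Compound 4 is therefore expected to show a step of about a 1.5-fold lower number from compound 3 to compound 4 (0.18 log units; within the scatter), within the scatter. The estimate for compound 4 in this assay is 3000 nM, with a range from 1400 nM to 6500 nM.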

Compound 4, inhibition constant: 5610 nM
Estimate against measurement, compound 4: 1.9-fold (0.27 log units) below, within the range that was stated.
By their numbers in this assay, from the lowest: compound 1; then compounds 2, 3 and 4 (each within the scatter of the next, the first and the last beyond it).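

In this assay, the change from benzyl to 4-chlorobenzyl gives a 1.2-fold higher number from compound 3 to compound 4 (0.09 log units; within the scatter) and so shows that chloro, like bromo, does not separate from hydrogen on this aromatic carbon. The two halogens do differ modestly from each other, with a 2.3-fold higher number from compound 2 to compound 4 (0.36 log units; beyond the scatter), even though each lies within the scatter of hydrogen. Nothing available explains this small gap between chloro and bromo.

From the compounds shown here alone, it remains open whether a different group at this place, such as methoxy, trifluoromethyl or an amine, would move the number beyond the scatter from hydrogen. Going by these compounds, it is also open whether the hydroxy on the saturated ring carbon matters as much with a halogen present as it does in a 15-fold higher number from compound 1 to compound 3 (1.17 log units; beyond the scatter), where the benzyl ring carries no halogen.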